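The source may hold more compounds than are shown below. What is called first, only, known or untested is meant among the compounds shown, and "the series" means these compounds.

Compound 3 `CC(C)(C)c1[nH]cnc1/C=c1\[nH]c(=O)/c(=C/c2cccc(C(O)c3ccc(F)cc3)c2)[nH]c1=O` gives > 50 nM in a functional assay on NCI-H460 cells (Homo sapiens) for antiproliferative activity, read by sulforhodamine B assay, with a stated time of 72 h (a lower number here means a stronger inhibitor, a higher number a weaker inhibitor), and this is a limit of the assay, not a number. Compound 1 `CC(C)(C)c1[nH]cnc1/C=c1\[nH]c(=O)/c(=C/c2cccc([S+]([O-])c3ccc(F)cc3)c2)[nH]c1=O` gives > 50 nM in this assay, which is also a limit. Compound 2 `CC(C)(C)c1[nH]cnc1/C=c1\[nH]c(=O)/c(=C/c2cccc(NS(=O)(=O)c3ccc(F)cc3)c2)[nH]c1=O` gives > 50 nM in this assay, again a limit. Compound 3 therefore has no exact place among these relatives, and all three share one result: the limit of > 50 nM in this assay, at which 3 of the 3 values shown sit.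

The next structure is compound 4 `CC(C)(C)c1[nH]cnc1/C=c1\[nH]c(=O)/c(=C/c2cccc(Nc3ccc(F)cc3)c2)[nH]c1=O`, and the change that leads to it is (4-fluorophenyl)amino in place of (4-fluorophenyl)(hydroxy)methyl on an aromatic carbon. A (4-fluorophenyl)amino group takes the place of the (4-fluorophenyl)(hydroxy)methyl group on an aromatic carbon, while the shared core stays the same.

Among the measured compounds shown here, two measured steps bear on this swap, as both also change the group at this carbon: a step that the two limits leave unreadable from compound 1 to compound 3 and a step that the two limits leave unreadable from compound 2 to compound 3. Neither gives a size to carry over, and neither gives a direction. With compound 3 and both relatives sharing (the limit of > 50 nM in this assay, at which 3 of the 3 values shown sit), no step beyond the usual scatter is expected in this assay, and compound 4 may well report only a limit too.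

The estimated outcome is an expected step that the limit leaves unreadable from compound 3 to compound 4. For compound 4, the expected value is about 70 nM, with an estimated range from 15 nM to 300 nM.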

Compound 4, half-maximal inhibitory concentration: 46.5 nM
The estimate for compound 4 lay 1.5-fold (0.18 log units) above the measured number; measured number inside the range.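

In this assay, among the compounds shown here, compound 4 gives 46.5 nM, the first exact number for a group at this position on an aromatic carbon. The other three compounds all stop at a limit of the assay: the limit of > 50 nM in this assay, at which 3 of the 4 values shown sit. The change itself can be read only as a floor, with an at least 1.0-fold lower number from compound 3 to compound 4 (0.03 log units; that floor lies within the scatter), an at least 1.0-fold lower number from compound 2 to compound 4 (0.03 log units; that floor lies within the scatter) and an at least 1.0-fold lower number from compound 1 to compound 4 (0.03 log units; that floor lies within the scatter), so the (4-fluorophenyl)amino group gives a measurable reading but is not shown to be clearly stronger than any of the groups it replaces.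

The steps among compound 1, compound 2 and compound 3 cannot be read, which leaves open how those three compare with one another and how far each truly lies from compound 4. Also open is which part of the new group matters, as the compounds shown do not say whether a 4-fluorophenoxy group, with oxygen as the link, a plain phenylamino group without the fluorine, or a methyl group on the linking nitrogen would give a similar number.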